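This account rests on a few compounds, and the source may have more. Where it says the series, first, only, none or still open, it means among the compounds named here.

Measured in a functional assay on HepG2 cells (Homo sapiens) for inhibition, read by MTT assay, with a stated time of 48 h (a higher number here means a weaker inhibitor, a lower number a stronger inhibitor), so far:
compound 1 `N#Cc1c(-c2ccc(Cl)cc2)nc2c(c(-c3ccccc3)nn2-c2ccccc2)c1-c1ccc(N2CCCCC2)cc1` gives 3210 nM
compound 2 `COc1ccc(-c2ccnc3c2c(-c2ccccc2)nn3-c2ccccc2)cc1` gives 6590 nM
compound 3 `CN1CCN(c2ccc(-c3c(C#N)c(-c4ccc(Cl)cc4)nc4c3c(-c3ccccc3)nn4-c3ccccc3)cc2)CC1` gives 14600 nM

Compound 3 has the highest number of the three, with compound 2 nearest to it and compound 1 furthest away. Next in the series is compound 4 `CN1CCN(c2ccc(-c3c(C#N)c(-c4ccccc4)nc4c3c(-c3ccccc3)nn4-c3ccccc3)cc2)CC1` with one change from compound 3: hydrogen in place of chloro on an aromatic carbon which is hydrogen in place of chloro on an aromatic carbon of a six-membered aromatic ring of carbon only, para to a large group.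

Going by the values given here, one measured step bears on the series, and only indirectly: a 4.5-fold higher number from compound 1 to compound 3 (0.66 log units; beyond the scatter) with 4-methylpiperazin-1-yl in place of piperidin-1-yl. That step lies at a different place on the molecule. Among the compounds with values here, no measured pair shows 4-chlorophenyl to phenyl, so the data give neither a size nor a direction for this change. No step beyond the scatter is therefore expected in this assay and the uncertainty remains wide in both directions. Within the data shown here, the estimate stays close to compound 3 at 14600 nM as the only measured compound with the same 4-methylpiperazin-1-yl group. The expected step is a 1.1-fold lower number from compound 3 to compound 4 (0.05 log units; within the scatter) in this estimate. The estimated value for compound 4 is 13000 nM with an expected range from 5000 nM to 35000 nM for the measurement.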

Compound 4, half-maximal inhibitory concentration: 3140 nM
Beside the measured number, compound 4's estimate is 4.1-fold (0.62 log units) above it; the whole stated range lies above it.
By their numbers in this assay, from the lowest: compounds 4 and 1 (each within the scatter of the next); then compound 2; then compound 3.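

In this assay, going by these compounds alone, this is the first measured step at the carbon para to a large group on the 4-chlorophenyl ring, and it gives the change a direction and a size: going from 4-chlorophenyl to phenyl, with the 4-methylpiperazin-1-yl group held constant, gives a lower number (a 4.6-fold lower number from compound 3 to compound 4 (0.67 log units; beyond the scatter)). Within the data shown here, the single chloro at this position therefore matters in this assay, and the earlier step at the other site (a 4.5-fold higher number from compound 1 to compound 3 (0.66 log units; beyond the scatter)) is no longer the only measured change beyond the scatter, though that step runs towards a higher number. Nothing available gives a reason for the new step, so it stands as an observation from one matched pair.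

Still open, as far as these compounds go, is whether the same loss of chloro would give a similar step with the piperidin-1-yl group of compound 1, or whether it depends on the 4-methylpiperazin-1-yl group. Also open, from the compounds shown here alone, is how a fluoro, a bromo, a methoxy or an amine on the same aromatic carbon would compare with chloro and hydrogen.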